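Swapping phenyl for furan-2-yl on a shared nucleoside core

The compounds below may be only part of what the source reports. "The series", "measured", "known", "first", "only" and "open" are said of these compounds alone.

Compound 1 `Nc1nc2c(c(-c3ccccc3)cn2[C@@H]2O[C@H](CO)[C@@H](O)[C@H]2O)c(=O)[nH]1` gives > 100000 nM in an ADME assay on BJ cells (Homo sapiens), read by MTT assay, with a stated time of 72 h (a higher number here means a weaker inhibitor, a lower number a stronger inhibitor), a limit of the assay rather than a number.
Compound 2 `Nc1nc(N)c2c(-c3ccccc3)cn([C@@H]3O[C@H](CO)[C@@H](O)[C@H]3O)c2n1` gives > 100000 nM in this assay, again a limit.
Compound 3 `Cc1nc(N)c2c(-c3ccccc3)cn([C@@H]3O[C@H](CO)[C@@H](O)[C@H]3O)c2n1` gives > 100000 nM in this assay, also a limit.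

Compound 3 therefore sits at the limit, alongside the other two measured compounds (the limit of > 100000 nM in this assay, at which 3 of the 3 values shown sit). Within the data shown here, the only single-point step available, a step that the two limits leave unreadable from compound 2 to compound 3, cannot be sized because both ends are limits. The change to compound 4 `Cc1nc(N)c2c(-c3ccco3)cn([C@@H]3O[C@H](CO)[C@@H](O)[C@H]3O)c2n1` is furan-2-yl in place of phenyl on an aromatic carbon. Among the measured compounds shown here, no measured step shows what this exchange does in this assay, so no shift beyond the scatter is expected. The expected step that the limit leaves unreadable from compound 3 to compound 4 is essentially none. Compound 4 is estimated at 150000 nM, within 50000 nM to 500000 nM, most likely reported as a limit.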

Compound 4, half-maximal inhibitory concentration: > 100000 nM
Compound 4: a limit, no number; the forecaster's own chance of this, stated with the estimate: 85%; the middle value does not contradict the limit.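

Compound 3 and compound 4 both give a limit rather than a number, so the step from phenyl to furan-2-yl cannot be read: the limit of > 100000 nM in this assay, at which 4 of the 4 values shown sit.

The compounds shown leave open which change to the shared core, if any, would give a measurable value in this assay.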